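Chain Extension on the Chlorinated Hydroxamic Acid Core

A few compounds are considered here, and "the series" means these few. Any claim that something is new, unique, unknown or untested is made for them only; others in the source may bear on it.

Compound 1 `O=C(CCCCCn1cc(Nc2ncc3ccn(Cc4ccccc4)c3n2)cn1)NO` gives 13.8 nM in an assay on isolated protein for inhibition of protein deacetylase HDAC6 (Homo sapiens), with a stated time of 60 min; on this read-out higher numbers stand for weaker inhibition and lower numbers for stronger inhibition.
Compound 2 `O=C(CCCCCCn1cc(Nc2ncc3ccn(Cc4ccccc4)c3n2)cn1)NO` gives 12.5 nM in this assay.
Compound 3 `O=C(CCCCCn1cc(Nc2ncc3ccn(Cc4cccc(Cl)c4)c3n2)cn1)NO` gives 34.4 nM in this assay.

Compound 4 `O=C(CCCCCCn1cc(Nc2ncc3ccn(Cc4cccc(Cl)c4)c3n2)cn1)NO` has not yet been measured in this assay. It differs from compound 3 in one place: (hydroxycarbamoyl)methyl in place of hydroxycarbamoyl on a saturated chain carbon, five bonds along the chain from an aromatic nitrogen. The same change has been made once before, from compound 1 to compound 2, where it produced a 1.1-fold lower number from compound 1 to compound 2 (0.04 log units; within the scatter). The core of compound 3 differs from that of compound 1 by chloro in place of hydrogen on an aromatic carbon, a change that gave a 2.5-fold higher number from compound 1 to compound 3 (0.40 log units; beyond the scatter), so compound 3 stands with the highest number of the three measured compounds.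

Since the step from compound 1 to compound 2 stayed within the scatter, compound 4 is expected to show a similarly small movement from compound 3, that is a 1.1-fold lower number from compound 3 to compound 4 (0.05 log units; within the scatter), resting on the outcome of a 1.1-fold lower number from compound 1 to compound 2 (0.04 log units; within the scatter). Compound 4 is therefore estimated to give 31 nM in this assay, with a plausible range from 16 nM to 62 nM, though this rests on a single earlier instance of the change.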

Compound 4, half-maximal inhibitory concentration: 36.8 nM
Compound 4: middle estimate off by 1.2-fold (0.07 log units), on the low side; low and high end bracket the measured number.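

In this assay, hydroxycarbamoyl replaced by (hydroxycarbamoyl)methyl gave a 1.1-fold higher number from compound 3 to compound 4 (0.03 log units; within the scatter), and this change carried over from one core to the other: the same change on two cores in this assay, a 1.1-fold lower number (0.04 log units; within the scatter) from compound 1 to compound 2 and a 1.1-fold higher number (0.03 log units; within the scatter) from compound 3 to compound 4, 1.2-fold (0.07 log units) apart, within the scatter of two such steps. Chloro in place of hydrogen on an aromatic carbon also carried over, giving a 2.9-fold higher number from compound 2 to compound 4 (0.47 log units; beyond the scatter) on the longer chain: the same change on two cores in this assay, a 2.5-fold higher number (0.40 log units; beyond the scatter) from compound 1 to compound 3 and a 2.9-fold higher number (0.47 log units; beyond the scatter) from compound 2 to compound 4, 1.2-fold (0.07 log units) apart, within the scatter of two such steps. Across these four compounds, therefore, each change gave a similar result whichever form the other part of the molecule took, but each comparison rests on only a single pair of cores and does not show that either result would hold on any other core.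

The compounds shown leave open whether a longer chain, such as 3-(hydroxycarbamoyl)propyl in place of (hydroxycarbamoyl)methyl at the same carbon, would also leave the number in the same range. They also leave open whether a fluoro or a methoxy group in place of the chloro would raise the number as the chloro does.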